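The source may report more compounds than this note shows. Statements on the series, on what has been measured and on what is new or still open speak of the compounds shown alone.

Measured so far:
compound 1 `NC(=S)c1c(N)n(COCc2ccccc2)c2ncnc(N)c12` — 225000 nM
compound 2 `COCCOCn1c(Br)c(C#N)c2c(N)ncnc21` — > 100000 nM

Among the compounds with values here, compound 1 carries the only number in a functional assay on KB cells (Homo sapiens) for inhibition (a higher number here means a weaker inhibitor, a lower number a stronger inhibitor), where compound 1 gives 225000 nM. For compound 2 the reading in this assay is a limit, not a number: compound 2 sits at > 100000 nM, as recorded in the limit of > 100000 nM in this assay, at which 1 of the 2 values shown sits. Compound 3 `N#Cc1c(N)n(COCc2ccccc2)c2ncnc(N)c12` differs from compound 1 by a group of 2 heavy atoms (1 carbon, 1 nitrogen; no ring) in place of a group of 3 heavy atoms (1 carbon, 1 nitrogen, 1 sulfur; no ring), on an aromatic carbon. Within the data shown here, no step between measured compounds is available to size this exchange of the thioamide for a cyano group. Compound 3 is expected to remain weak in this assay, estimated at 300000 nM with a range from 100000 nM to 1000000 nM, the expected step of a 1.3-fold higher number from compound 1 to compound 3 (0.12 log units; within the scatter) lying within the scatter. A limit instead of a number is a real possibility.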

Compound 3, half-maximal inhibitory concentration: 118000 nM
Beside the measured number, compound 3's estimate is 2.5-fold (0.41 log units) above it; low and high end bracket the measured number.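

In this assay, exchanging the thioamide for cyano on this aromatic carbon gives a 1.9-fold lower number from compound 1 to compound 3 (0.28 log units; within the scatter). The hydrogen-bond donor of the thioamide is therefore lost without a change beyond the scatter, and this exchange does not separate the two compounds. For compound 2 the reading is a limit, not a number: the limit of > 100000 nM in this assay, at which 1 of the 3 values shown sits.

Open, from the compounds shown here alone, is whether a carboxylic acid or an amine on this aromatic carbon would shift the number beyond the scatter. Also open, going by these compounds, is what a shorter chain would do in place of the chain that compound 1 and compound 3 share.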